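Urea to amide: a pyrazole series at one concentration

The source may report more compounds than this note shows. Statements on the series, on what has been measured and on what is new or still open speak of the compounds shown alone.

Compound 1 `O=C(Nc1cccc(-n2cc(-c3ccncc3)c(-c3cc(O)cc(Cl)c3)n2)c1)Nc1ccc(Cl)c(C(F)(F)F)c1`: 95%
Compound 2 `O=C(Nc1cccc(-n2cc(-c3ccncc3)c(-c3cc(O)cc(Cl)c3)n2)c1)Nc1ccc(Cl)c(Cl)c1`: 85%
Compound 3 `COc1cc(Cl)cc(-c2nn(-c3cccc(NC(=O)Nc4ccc(Cl)c(Cl)c4)c3)cc2-c2ccncc2)c1`: 101%

Three compounds share a core and were tested in a functional assay on RXF 393 cells (Homo sapiens) for inhibition, read by sulforhodamine B assay, with a stated time of 48 h, tested at 0.1 uM; on this read-out higher numbers stand for a weaker effect at the one concentration tested and lower numbers for a stronger effect. Compound 1 gives 95%, compound 2 gives 85% and compound 3 gives 101%. Compound 3 stands highest of the three; its gap to compound 1 is within the scatter, while the step of a number 16 percentage points higher from compound 2 to compound 3 (beyond the scatter) lies beyond it. The step of a number 10 percentage points lower from compound 1 to compound 2 (within the scatter) is within the scatter.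

Compound 4 `COc1cc(Cl)cc(-c2nn(-c3cccc(NC(=O)c4cccc(C(F)(F)F)c4)c3)cc2-c2ccncc2)c1` differs from compound 3 by 3-(trifluoromethyl)phenyl in place of (3,4-dichlorophenyl)amino on a carbonyl carbon. Neither measured step touches this position: the step from compound 1 to compound 2 exchanges groups on the outer aromatic ring, and the step from compound 2 to compound 3 alters the oxygen on the other ring. Within the data shown here, no measured pair shows what replacing the (3,4-dichlorophenyl)amino group with 3-(trifluoromethyl)phenyl does. Since all three measured numbers sit near the top of the scale, compound 4 is expected to stay there too, with a step of a number 5 percentage points lower from compound 3 to compound 4 (within the scatter) that is estimated not to exceed the scatter. Compound 4 is therefore estimated at 96%, with a range from 78% to 110%.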

Compound 4, a percentage reported as activity, at one concentration (the size of the read-out at that concentration, not a potency): 65%
For compound 4 the middle estimate is 31 percentage points above the measured one; measured number outside the range, below it.
By their numbers in this assay, from the lowest: compound 4; then compounds 2, 1 and 3 (each within the scatter of the next, the first and the last beyond it).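

Among these compounds, at the carbonyl carbon, replacing (3,4-dichlorophenyl)amino with 3-(trifluoromethyl)phenyl gives a number 36 percentage points lower from compound 3 to compound 4 (beyond the scatter) in this assay, so this position can clearly shift the read-out, which the earlier compounds, all keeping the urea, could not show. The change removes the nitrogen and its hydrogen-bond donor and also alters the substituents on the outer ring, so this single step cannot separate the two contributions. Nothing measured here explains the drop in the number.

The compounds shown leave open whether the amide would behave the same way with a 3,4-dichlorophenyl ring, or with a hydroxy group in place of the methoxy group of compound 4. They also leave open what a morpholine, a piperazine or a carboxylic acid on the outer ring would do.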